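This account rests on a few compounds, and the source may have more. Where it says the series, first, only, none or still open, it means among the compounds named here.

Measured so far in an ADME assay on Raji cells (Homo sapiens) for cytotoxicity, read by CellTiter-Glo and resazurin assay, with a stated time of 72 h; on this read-out lower numbers stand for an effect already at smaller amounts and higher numbers for an effect only at larger amounts of compound:
- compound 1 `CC(C)N(Cc1cccc(OCCCCCC(=O)O)c1)C(=O)c1ccccc1`, a limit of the assay: > 26000 nM
- compound 2 `CC(C)N(Cc1cccc(OCCCCCC(=O)O)c1)C(=O)c1ccc(-c2cccc(Oc3ccccc3)c2)cc1`, a limit of the assay: > 18700 nM
- compound 3 `CC(C)N(Cc1cccc(OCCCCCC(=O)O)c1)C(=O)c1ccc(-c2ccsc2)cc1`, a limit of the assay: > 26000 nM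

Compound 3 stands at a limit, as do the two further values shown, so no number places it against the others. For the measured compounds named here, the only single-place step, a step that the two limits leave unreadable from compound 1 to compound 3, is left unreadable by the two limits. Two of the three values sit at the limit of > 26000 nM in this assay, at which 2 of the 3 values shown sit, and one at the limit of > 18700 nM in this assay, at which 1 of the 3 values shown sits. Compound 4 `CC(C)N(Cc1cccc(OCCCCCC(=O)O)c1)C(=O)c1ccc(-c2c[nH]c3ccccc23)cc1` carries the change (1H-indol-3-yl in place of thiophen-3-yl on an aromatic carbon). Going by the values given here, no measured step bears on this change with a readable size, so no direction in this assay can be expected beyond the scatter, and a limit is the most likely outcome for compound 4. Compound 4 is expected at 30000 nM, range 10000 nM to 100000 nM. The expected step is then a step that the limit leaves unreadable from compound 3 to compound 4.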

Compound 4, half-maximal effective concentration: > 26000 nM
Compound 4: only a limit was reported; the forecaster's own chance of this, stated with the estimate: 85%; the middle value does not contradict the limit.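

Compound 4 gives only a limit of the assay, as do compound 1 and compound 3, so neither step to compound 4 can be read. The compounds shown leave open at what concentration any of them takes effect.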